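The source may hold more compounds than are shown below. What is called first, only, known or untested is meant among the compounds shown, and "the series" means these compounds.

In a functional assay on L1210 cells (Mus musculus) for inhibition (a lower number here means a stronger inhibitor, a higher number a weaker inhibitor), three compounds have been measured:

Compound 1 `Nc1ncnc2c1ncn2C/C=C/CCl`: 45000 nM
Compound 2 `Nc1ccn(C/C=C\CCl)c(=O)n1`: 10000 nM
Compound 3 `Nc1ccn(C=C=CCO)c(=O)n1`: 560000 nM

Compound 1 holds the middle place among these three numbers. Compound 2 lies lower and compound 3 lies higher, and both gaps are beyond the scatter. The compound still to be measured is compound 4 `Nc1ncnc2c1ncn2CC#CCO`. It keeps the core of compound 1 and carries 3-hydroxyprop-1-yn-1-yl in place of 3-chloroprop-1-en-1-yl on a saturated chain carbon bound to an aromatic nitrogen.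

Among the measured compounds shown here, no measured pair isolates this change, so the evidence is indirect. For the measured compounds named here, compound 3 is the only measured compound with a hydroxy group, and it gives 560000 nM. The two chlorine-bearing compounds have lower numbers, with compound 1 at 45000 nM and compound 2 at 10000 nM. However, compound 3 differs from compound 1 in its core as well as its chain, so it is only a loose guide. A move towards weaker inhibition, beyond the scatter, is therefore expected, and the expected step is a 4.4-fold higher number from compound 1 to compound 4 (0.65 log units; beyond the scatter). The estimate for compound 4 is 200000 nM, with an expected range from 60000 nM to 650000 nM.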

Compound 4, half-maximal inhibitory concentration: 490000 nM
Compound 4: middle estimate off by 2.5-fold (0.39 log units), on the low side; the measured number falls inside the stated range.
By their numbers in this assay, from the lowest: compound 2; then compound 1; then compounds 4 and 3 (each within the scatter of the next).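

In this assay, putting 3-hydroxyprop-1-yn-1-yl in place of 3-chloroprop-1-en-1-yl on a saturated chain carbon bound to an aromatic nitrogen brings an 11-fold higher number from compound 1 to compound 4 (1.04 log units; beyond the scatter) on the core of compound 1. This is the only step shown at this position, and it shows that inhibition responds strongly to the chain even though both groups have the same count of heavy atoms. The group that enters has a triple bond, oxygen, a hydrogen-bond donor and a hydrogen-bond acceptor, while the group that leaves has a double bond, chlorine and neither donor nor acceptor, and no supporting measurement ties the step to any of these differences.

The step changes the chain end and its unsaturated bond in a single move, so the compounds shown leave open which change accounts for it; 4-hydroxybut-2-en-1-yl or 4-chlorobut-2-yn-1-yl on the same core would separate the two. As far as these compounds go, it also remains open whether a methoxy group or an amine at the chain end would give a number closer to that of the chlorine compound or the hydroxy compound.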